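The source may report more compounds than this note shows. Statements on the series, on what has been measured and on what is new or still open speak of the compounds shown alone.

The series shares one core and varies only the group on the carbonyl carbon of the amide. Compound 1 `N#CC1=C(NC(=O)C2CC2)N(c2ccc(S(N)(=O)=O)cc2)C2=C(C(=O)CCC2)C1c1ccc(Cl)cc1Cl` carries cyclopropyl there; in a functional assay on Ehrlich cells (Mus musculus) for cytotoxicity, read by trypan blue exclusion, with a stated time of 2 h (on this read-out higher numbers stand for weaker inhibition and lower numbers for stronger inhibition), compound 1 gives 75 ug/mL. Compound 2 `N#CC1=C(NC(=O)c2ccccc2)N(c2ccc(S(N)(=O)=O)cc2)C2=C(C(=O)CCC2)C1c1ccc(Cl)cc1Cl` carries phenyl, and in this assay compound 2 gives 10 ug/mL. Compound 3 `N#CC1=C(NC(=O)/C=C/c2ccccc2)N(c2ccc(S(N)(=O)=O)cc2)C2=C(C(=O)CCC2)C1c1ccc(Cl)cc1Cl` carries 2-phenylethenyl. In this assay compound 3 reaches only a limit, > 100 ug/mL, not a number. The measured steps read: a 7.5-fold lower number from compound 1 to compound 2 (0.88 log units; beyond the scatter); an at least 1.3-fold higher number from compound 1 to compound 3 (0.12 log units; that floor lies within the scatter); an at least 10-fold higher number from compound 2 to compound 3 (1.00 log units; beyond the scatter). Compound 4 `N#CC1=C(NC(=O)c2ccc([N+](=O)[O-])cc2)N(c2ccc(S(N)(=O)=O)cc2)C2=C(C(=O)CCC2)C1c1ccc(Cl)cc1Cl` differs from compound 3 by 4-nitrophenyl in place of 2-phenylethenyl on a carbonyl carbon. This change largely reverses the phenyl to 2-phenylethenyl step, so for compound 4 a lower number is expected in this assay, roughly an at least 6.6-fold lower number from compound 3 to compound 4 (0.82 log units; beyond the scatter). Compound 4 is therefore estimated at 15 ug/mL, with a likely range from 5 ug/mL to 60 ug/mL.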

Compound 4, half-maximal inhibitory concentration: 50 ug/mL
Compound 4: the middle estimate sits 3.3-fold (0.52 log units) below what was measured, within the range that was stated.
By their numbers in this assay, from the lowest: compound 2; then compounds 4 and 1 (each within the scatter of the next). At a limit, above all of these: compound 3.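

In this assay, within the data shown here, nitro in place of hydrogen on an aromatic carbon is the first change made on the phenyl of compound 2 rather than swapping the whole group, and it matters: a 5.0-fold higher number from compound 2 to compound 4 (0.70 log units; beyond the scatter). A phenyl on the carbonyl carbon therefore does not alone secure the low number of compound 2, and with a 1.5-fold lower number from compound 1 to compound 4 (0.18 log units; within the scatter), 4-nitrophenyl and cyclopropyl are not separated. The remaining step is an at least 2.0-fold lower number from compound 3 to compound 4 (0.30 log units; that floor lies within the scatter), and compound 3 gives only a limit, not a number: the limit of > 100 ug/mL in this assay, at which 1 of the 4 values shown sits.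

Open, on these data alone, is whether an amine or a carboxylic acid on that phenyl would move the number as nitro does. Also open, as far as these compounds go, is whether a saturated 2-phenylethyl chain would behave like 2-phenylethenyl.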